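The compounds below may be only part of what the source reports. "The series", "measured", "known", "first", "only" and "open" are said of these compounds alone.

Measured so far:
compound 1, `CCCn1c(Br)nc2c(N)nc(NCCCc3ccccc3)nc21`, 6300 nM
compound 2, `CCCn1cnc2c(NCc3ccccc3)ncnc21`, > 30000 nM

In a functional assay on CHO cells for antagonist activity at adenosine receptor A2b (Homo sapiens) (a lower number here means a stronger inhibitor, a higher number a weaker inhibitor), compound 1, `CCCn1c(Br)nc2c(N)nc(NCCCc3ccccc3)nc21`, gives 6300 nM. Compound 2, `CCCn1cnc2c(NCc3ccccc3)ncnc21`, gives > 30000 nM in this assay, which is a limit of the assay and not a number. Among the measured compounds shown here, compound 2 therefore stands at the limit of > 30000 nM in this assay, at which 1 of the 2 values shown sits, so only a range is known for it, and no step between measured compounds can be drawn. Compound 3, `CCCn1c(Br)nc2c(NCc3ccccc3)ncnc21`, differs from compound 2 by bromo in place of hydrogen on an aromatic carbon. Compound 1 also carries a bromo group, yet it differs from compound 3 in other places too, so its value cannot be read as the effect of the bromo group alone. The step of an at least 1.5-fold lower number from compound 2 to compound 3 (0.17 log units; that floor lies within the scatter) is expected to lean toward stronger inhibition, though with wide uncertainty. Compound 3 is estimated to give 20000 nM in this assay, with a range from 5000 nM to 60000 nM, and a sizable chance that only a limit is reported again.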

Compound 3, inhibition constant: 7490 nM
Compound 3: middle estimate off by 2.7-fold (0.43 log units), on the high side; the range from low to high includes it.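

Bromo in place of hydrogen on an aromatic carbon, at the spot between two ring nitrogen atoms and next to the ring atom that bears a propyl group, brings an at least 4.0-fold lower number from compound 2 to compound 3 (0.60 log units; beyond the scatter). Among the compounds shown here, this gives the first reading of this position in this assay: a change at this one carbon is enough to turn a compound known only by a limit into one with a measured value. The step gives only a floor for the effect of bromo, because compound 2 is held at a limit of the assay and not at a number: the limit of > 30000 nM in this assay, at which 1 of the 3 values shown sits.

On these data alone, how large the effect of bromo really is remains open. So does whether chloro, methyl or an amine on the same carbon would act as bromo does, and compound 1 differs from compound 3 in more than one place, so it does not settle this.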